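The source may report more compounds than this note shows. Statements on the series, on what has been measured and on what is new or still open speak of the compounds shown alone.

Of the compounds shown here, three that share one core have been tested in an ADME assay on Vero cells (Chlorocebus sabaeus) for cytotoxicity, read by neutral red uptake, tested at 3150 ug/mL; a higher number here means a weaker effect of the compound at the concentration tested, a lower number a stronger effect. Compound 1 `O=C1CSC(c2c(Cl)cccc2Cl)N1CCN1CCCCC1` gives 7% in this assay. Compound 2 `COc1ccccc1C1SCC(=O)N1CCN1CCCCC1` gives 5% in this assay. Compound 3 `Cc1ccc(C2SCC(=O)N2CCN2CCCCC2)cc1` gives 12% in this assay. None of the three numbers stands apart from the others: the gap between compound 3 and compound 1, and the gap between compound 3 and compound 2, both lie within the usual scatter of repeated measurements, so no ranking can be read from them, and all three numbers speak of a weak effect at the concentration tested.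

Compound 4 `O=C1CSC(c2ccccc2Cl)N1CCN1CCCCC1` has not yet been measured in this assay. It differs from compound 3 in one place: 2-chlorophenyl in place of 4-methylphenyl on a saturated ring carbon. The same kind of group already appears in compound 1, whose number of 7% sits within the scatter of the number for compound 3.

Since no change among the three measured compounds moved this assay beyond the scatter, the step expected in this assay from compound 3 to compound 4 is a number 5 percentage points lower from compound 3 to compound 4 (within the scatter), which means none beyond the scatter. The estimate for compound 4 is therefore 7%, expected to fall between 1% and 17%.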

Compound 4, a percentage reported as activity, at one concentration (the size of the read-out at that concentration, not a potency): 22%
The estimate for compound 4 lay 15 percentage points below the measured number; the measured number lies above the stated range.
By their numbers in this assay, from the lowest: compounds 2, 1, 3 and 4 (each within the scatter of the next, the first and the last beyond it).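

The aromatic group on the saturated ring carbon can shift the result measurably in this assay, which the first three compounds did not show. Two single changes on the aromatic ring move the number beyond the scatter, each modestly: hydrogen in place of chloro gives a number 15 percentage points higher from compound 1 to compound 4 (beyond the scatter), and chloro in place of methoxy gives a number 17 percentage points higher from compound 2 to compound 4 (beyond the scatter), so compound 4 has a weaker effect at the concentration tested than either neighbour. The exchange of 4-methylphenyl for 2-chlorophenyl is less clear, since a number 10 percentage points higher from compound 3 to compound 4 (within the scatter) does not separate those two compounds, and no measurement shown explains any of these steps.

The compounds shown leave open whether a different group on the aromatic ring, such as an amine or a carboxylic acid, would move the number further than chloro, methoxy or methyl do. They also say nothing about a change elsewhere on the shared core. This read-out comes from a single concentration. It gives the size of the effect there and not a potency.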